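The source may hold more compounds than are shown below. What is called first, only, known or untested is meant among the compounds shown, and "the series" means these compounds.

Within the data shown here, in an assay on isolated protein for inhibition of DNA topoisomerase 1 (Homo sapiens), with a stated time of 30 min, tested at 100 uM (a lower number here means less inhibition, a higher number more inhibition at the concentration tested (going by the name of the read-out)), compound 3 `Cc1ccc(-c2cc(-c3ccoc3)cc(-c3ccc(Cl)s3)n2)cc1` gives 0%, the lowest of the three numbers so far, though every number sits within the scatter of it: compound 1 `Cc1ccsc1-c1cc(-c2ccco2)cc(-c2ccccc2Cl)n1` gives 2%, and compound 2 `Cc1ccccc1-c1cc(-c2ccoc2)cc(-c2ccc(Cl)s2)n1` gives 4.6%. Among the measured compounds shown here, the only measured step, a number 4.6 percentage points lower from compound 2 to compound 3 (within the scatter), also stays within the scatter. Compound 4 `Clc1ccc(-c2cc(-c3ccoc3)cc(-c3cccnc3)n2)s1` differs from compound 3 by pyridin-3-yl in place of 4-methylphenyl on an aromatic carbon. For the measured compounds named here, no measured step covers a change of this kind, so the expectation rests only on the flatness of the three values, which all lie near the bottom of the scale. The step from compound 3 to compound 4 is therefore expected to stay within the scatter, a number 3 percentage points higher from compound 3 to compound 4 (within the scatter). For compound 4 the estimated value is 3%, with a range from 0% to 12%.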

Compound 4, a percentage reported as inhibition, at one concentration (the size of the read-out at that concentration, not a potency): 2%
Compound 4: the middle estimate sits 1 percentage points above what was measured; measured number inside the range.
By their numbers in this assay, from the lowest: compounds 3, 1, 4 and 2 (each within the scatter of the next).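

In this assay, pyridin-3-yl brings a ring nitrogen and a hydrogen-bond acceptor to the place next to the ring nitrogen of the shared core, and the outcome is a number 2 percentage points higher from compound 3 to compound 4 (within the scatter) with no separation from 4-methylphenyl. Set against 2-methylphenyl at the same place, the outcome is a number 2.6 percentage points lower from compound 2 to compound 4 (within the scatter) and again shows no separation. Nothing measured here speaks to why these numbers stay so close. Still open, as far as these compounds go, is whether any group at this place can move the number clear of the scatter, for instance an amine or a carboxylic acid on the ring, or a longer alkyl chain in its stead.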